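Straight Chain in Place of Branched at the Ether

A few compounds are considered here, and "the series" means these few. Any claim that something is new, unique, unknown or untested is made for them only; others in the source may bear on it.

Measured compounds:
compound 1 `CC(C)COc1ccc2c(Cl)ccnc2c1` — 3190 nM
compound 2 `CCCCCCOc1ccc2c(NCCN(C)C)ccnc2c1` — 1860 nM
compound 3 `Fc1ccc(COc2ccc3c(Cl)ccnc3c2)cc1` — 2780 nM

Three compounds sharing the core of compound 1 have been run in a functional assay on SK-OV-3 cells (Homo sapiens) for cytotoxicity, read by MTT assay, with a stated time of 48 h; a higher number here means a weaker inhibitor, a lower number a stronger inhibitor. Compound 1 gives 3190 nM, the highest number of the three, though this says little: compound 3 gives 2780 nM and compound 2 gives 1860 nM, and neither gap from compound 1 reaches beyond the usual scatter, so no order among them can be read.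

The step under study leads to compound 4 `CCCCOc1ccc2c(Cl)ccnc2c1`, which has the same atoms as compound 1 joined differently: propyl in place of isopropyl on a saturated chain carbon bound to an oxygen on an aromatic ring. Within the data shown here, no pair of measured compounds differing in a single place is available, so there is no measured step to lean on. Across the three measured compounds, varied alkyl and aryl-methyl groups on the oxygen leave the numbers close together, and a propyl for isopropyl exchange is a smaller change than any of those. Compound 4 is therefore expected to sit near compound 1, with a step of a 1.1-fold lower number from compound 1 to compound 4 (0.03 log units; within the scatter) of no size beyond the scatter. The estimate for compound 4 is 3000 nM, within 1500 nM to 6000 nM.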

Compound 4, half-maximal inhibitory concentration: 4130 nM
For compound 4 the middle estimate is 1.4-fold (0.14 log units) below the measured one; measured number inside the range.
By their numbers in this assay, from the lowest: compounds 2, 3, 1 and 4 (each within the scatter of the next, the first and the last beyond it).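

Among these compounds, compound 1 and compound 4 form the first pair in the set that differs in one place only, which gives this position a direct reading for the first time. With propyl in place of isopropyl on a saturated chain carbon bound to an oxygen on an aromatic ring, this assay records a 1.3-fold higher number from compound 1 to compound 4 (0.11 log units; within the scatter) and so does not separate the two chains: rejoining the same atoms at this position produces no change that can be read. No separate measurement bears on this result.

Going by these compounds, whether any exchange at this oxygen can move the number beyond the scatter remains open. A much longer chain such as decyl, or a chain ending in a carboxylic acid or a morpholine, would test this against the core of compound 1.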